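Ethoxy to carboxy on the benzamide ring

The source may report more compounds than this note shows. Statements on the series, on what has been measured and on what is new or still open speak of the compounds shown alone.

Of the compounds shown here, two have been measured. Compound 1 `CC(=O)c1ccc(OCC(=O)Nc2cccc(NC(=O)c3ccc(N(C)C)cc3)c2)cc1F` in an assay on isolated protein for inhibition of Rho-associated protein kinase 1 (Homo sapiens), read by scintillation counting, radiometric assay and 33P incorporation, with a stated time of 40 min, in the presence of a further agent that is not named here (on this read-out higher numbers stand for weaker inhibition and lower numbers for stronger inhibition), gives 445 nM. Compound 2 `CCOc1ccc(C(=O)Nc2cccc(NC(=O)COc3ccc4c(=O)ccoc4c3)c2)cc1` in this assay gives 17 nM, the lowest of the two numbers; its gap to compound 1 lies beyond the scatter, so compound 2 is the stronger inhibitor of the pair. Among the compounds with values here, the two compounds differ in several places at once, and no single-point step between measured compounds is available.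

Compound 3 `O=C(COc1ccc2c(=O)ccoc2c1)Nc1cccc(NC(=O)c2ccc(C(=O)O)cc2)c1` is not yet measured. It differs from compound 2 in one place: carboxy in place of ethoxy on an aromatic carbon. Within the data shown here, no measured pair shows this change, so its effect is unknown from the data in hand. The expected step from compound 2 to compound 3 in this assay is a modest weakening, a 3.5-fold higher number from compound 2 to compound 3 (0.55 log units; beyond the scatter), with a wide range of uncertainty. For compound 3 the estimate in this assay is 60 nM, with a range from 15 nM to 250 nM.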

Compound 3, half-maximal inhibitory concentration: 6890 nM
Compound 3: middle estimate off by 110-fold (2.06 log units), on the low side; the whole stated range lies below it.
By their numbers in this assay, from the lowest: compound 2; then compound 1; then compound 3.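

In this assay, within the data shown here, carboxy in place of ethoxy on the aromatic carbon para to a large group gives a 410-fold higher number from compound 2 to compound 3 (2.61 log units; beyond the scatter) as the first single-point step, and it is a large one. This position is therefore far from indifferent to the group it carries, even though ethoxy and carboxy each count 3 heavy atoms, so heavy-atom count alone does not track the change. No measurement available on the series bears on the reason for this loss.

On these data alone, whether a methyl ester or a primary amide on this carbon would stand nearer compound 2 or compound 3 remains open. So does the comparison of ethoxy with a longer alkoxy chain or with a simple methoxy at the same place.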